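A few compounds are considered here, and "the series" means these few. Any claim that something is new, unique, unknown or untested is made for them only; others in the source may bear on it.

Compound 1 `O=C1/C(=C/c2ccccc2)C(c2ccccc2)Oc2ccccc21`: 29500 nM
Compound 2 `O=C1/C(=C/c2ccc(O)cc2)COc2ccccc21`: 32300 nM
Compound 3 `O=c1c(Cc2ccc([N+](=O)[O-])cc2)coc2ccccc12`: 5000 nM

All three compounds were tested in a functional assay on NALM-6 cells (Homo sapiens) for cytotoxicity, read by MTT assay, with a stated time of 46 h; on this read-out lower numbers stand for stronger inhibition and higher numbers for weaker inhibition. Compound 3 stands lowest of the three at 5000 nM, and its distance to each of the other two lies beyond the usual scatter. Compound 1 and compound 2 lie within the scatter of each other.

The next compound, compound 4 `N#Cc1ccc(Cc2coc3ccccc3c2=O)cc1`, keeps the rest of compound 3 and carries cyano in place of nitro on an aromatic carbon, on a six-membered aromatic ring of carbon only, para to a large group: cyano in place of nitro on an aromatic carbon. Within the data shown here, no two measured compounds differ in only one place, so the data give no direct measure of such an exchange in this assay. Compound 1 and compound 2 differ from compound 3 in more than this group and offer little guidance.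

Among the measured compounds shown here, the only close anchor is compound 3 at 5000 nM. From it, a small step is expected, most likely within the scatter and leaning toward a higher number, meaning weaker inhibition. The estimated change is a 1.4-fold higher number from compound 3 to compound 4 (0.15 log units; within the scatter). For compound 4 the expected value is 7000 nM, with an estimated range from 2500 nM to 20000 nM.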

Compound 4, half-maximal inhibitory concentration in the NALM-6 assay: 4800 nM
For compound 4 the middle estimate is 1.5-fold (0.16 log units) above the measured one, and the stated range covers the measured number.
By their numbers in the NALM-6 assay, from the lowest: compounds 4 and 3 (each within the scatter of the next); then compounds 1 and 2 (each within the scatter of the next).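

Among these compounds, compound 3 and compound 4 form the first pair that differ in one place, so they give the first direct reading of an exchange on this aromatic carbon, para to a large group. In the NALM-6 assay, cyano in place of nitro gives a 1.0-fold lower number from compound 3 to compound 4 (0.02 log units; within the scatter), so at this position the two groups cannot be told apart in cytotoxicity, even though cyano brings fewer heavy atoms and fewer hydrogen-bond acceptors than nitro. In a physicochemical assay for lipophilicity, read by HPLC (on this read-out higher numbers stand for higher lipophilicity and lower numbers for lower lipophilicity), compound 3 gives 3.93 and compound 4 gives 3.58. The same exchange does separate the two compounds in lipophilicity, so this modest measured shift in the physicochemical assay came with no readable shift in the cell read-out for this pair: the measured partition coefficient of compound 3, 3.93, and of compound 4, 3.58, a number 0.35 log units lower (beyond the scatter)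

Nitro and cyano are the only two groups compared at this position, and a single pair cannot show whether the cell read-out would follow lipophilicity over a wider span. On these data alone, it remains open whether an amine or a carboxylic acid on the same carbon, or a bare carbon carrying only hydrogen, would leave the number where these two compounds stand.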